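Methyl-for-hydrogen step carried onto a second core

The source may report more compounds than this note shows. Statements on the series, on what has been measured and on what is new or still open speak of the compounds shown alone.

Measured so far:
compound 1, `CC=C(/C=C/c1ccc(OC)c(N)c1)c1cc(OC)c(OC)c(OC)c1`, 217 nM
compound 2, `CCC=C(/C=C/c1ccc(OC)c(N)c1)c1cc(OC)c(OC)c(OC)c1`, 314 nM
compound 3, `CC=C(/C(C)=C/c1ccc(OC)c(O)c1)c1cc(OC)c(OC)c(OC)c1`, 563 nM

In a functional assay on HeLa cells (Homo sapiens) for antiproliferative activity, read by MTT assay, with a stated time of 48 h (a lower number here means a stronger inhibitor, a higher number a weaker inhibitor), compound 1 gives 217 nM and compound 2 gives 314 nM. The change between them, (methyl in place of hydrogen on a saturated chain carbon bound to a double-bonded chain carbon), made a 1.4-fold higher number from compound 1 to compound 2 (0.16 log units; within the scatter). Compound 3 is built on a different core; the difference between the two cores is not broken down here. Compound 3 gives 563 nM, the highest of the three numbers: its gap to compound 1 is beyond the scatter, its gap to compound 2 within it.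

Compound 4, `CCC=C(/C(C)=C/c1ccc(OC)c(O)c1)c1cc(OC)c(OC)c(OC)c1`, is not yet measured. It differs from compound 3 by methyl in place of hydrogen on a saturated chain carbon bound to a double-bonded chain carbon, the same change, at the same place, as from compound 1 to compound 2; it occurs twice among the compounds here. The step from compound 3 to compound 4 in this assay is expected to be a 1.4-fold higher number from compound 3 to compound 4 (0.15 log units; within the scatter), which rests on the earlier step, a 1.4-fold higher number from compound 1 to compound 2 (0.16 log units; within the scatter), and on the single pairing in which it was measured. Compound 4 is therefore estimated at 800 nM, expected between 400 nM and 1600 nM.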

Compound 4, half-maximal inhibitory concentration: 3130 nM
For compound 4 the middle estimate is 3.9-fold (0.59 log units) below the measured one; measured number outside the range, above it.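

In this assay, the methyl-for-hydrogen change gave a 5.6-fold higher number from compound 3 to compound 4 (0.75 log units; beyond the scatter) on the second core, and its size does not match that of the same change on the first core: the same change on two cores in this assay, a 1.4-fold higher number (0.16 log units; within the scatter) from compound 1 to compound 2 and a 5.6-fold higher number (0.75 log units; beyond the scatter) from compound 3 to compound 4, 3.8-fold (0.58 log units) apart, beyond the scatter of two such steps

The change therefore does not carry across these two cores with a constant size, and only on the second core does the step lie beyond the scatter. The data do not show which feature of the cores sets the size of the step, as the core difference is not broken down into single changes, and with one pair per core they give no general rule for the series.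

Open, going by these compounds, is whether a longer chain, such as propyl, in the same place would raise the number further on either core. Also open, on these data alone, is which part of the core difference goes with the larger step, which would take compounds differing from compound 1 in one place at a time on the way to the core of compound 3.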